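Adding a chlorine to a weak monoamine oxidase A inhibitor

The compounds below may be only part of what the source reports. "The series", "measured", "known", "first", "only" and "open" are said of these compounds alone.

Of the compounds shown here, two have been measured in an assay on microsomes for inhibition of Amine oxidase [flavin-containing] A (Homo sapiens), read by fluorescence and spectrophotometry, with a stated time of 20 min; a lower number here means a stronger inhibitor, a higher number a weaker inhibitor. Compound 1 `N#Cc1ccc(SCc2ccccc2)cc1C#N` carries two nitrile groups on its core and gives 9020 nM. Compound 2 `N#Cc1ccc(SCc2ccccc2)cc1`, which keeps only one nitrile, gives 42400 nM, the highest of the two numbers and therefore the weaker inhibitor of the pair. That single change accounts for the whole difference: a 4.7-fold higher number from compound 1 to compound 2 (0.67 log units; beyond the scatter).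

Compound 3 `N#Cc1ccc(SCc2ccc(Cl)cc2)cc1` is not yet measured. It differs from compound 2 in one place: chloro in place of hydrogen on an aromatic carbon, sitting on a six-membered aromatic ring of carbon only. Within the data shown here, none of the measured steps touches this ring, so nothing seen so far speaks for or against the chlorine. Among the measured compounds shown here, the one measured step concerns a nitrile on a different ring and cannot be carried over.

Without guidance from the data, compound 3 is expected to stay close to compound 2, with a step no larger than a 1.4-fold lower number from compound 2 to compound 3 (0.15 log units; within the scatter), which lies within the usual scatter. The estimate for compound 3 in this assay is therefore 30000 nM, with a range from 9000 nM to 100000 nM.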

Compound 3, half-maximal inhibitory concentration: 20300 nM
For compound 3 the middle estimate is 1.5-fold (0.17 log units) above the measured one, within the range that was stated.
By their numbers in this assay, from the lowest: compound 1; then compound 3; then compound 2.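

In this assay, among these compounds, the chloro group in place of hydrogen gives a 2.1-fold lower number from compound 2 to compound 3 (0.32 log units; beyond the scatter) on a ring that no earlier step touched, so this ring is also a place where a change can move the read-out. The new group sits para to a large group and is a single chlorine atom with no hydrogen-bond donors or acceptors, yet that small change takes the number beyond the usual scatter, although the step remains modest. No measurement at hand explains why the number falls, so the step stands as an observation only.

On these data alone, it remains open whether chlorine matters in particular or whether other groups at this position, such as fluorine, methoxy or an amine, would move the number in the same direction, by a similar amount or not at all. As far as these compounds go, it is also open whether the chlorine step would carry over to the core of compound 1, with its second nitrile, since a single pair of compounds cannot show whether the two changes would add together.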